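The source may hold more compounds than are shown below. What is called first, only, known or untested is meant among the compounds shown, and "the series" means these compounds.

Among the three compounds measured so far, compound 3 `COc1ccc(F)c(-c2ccc(S(=O)(=O)Nc3cc(N4C[C@@H](C)N[C@@H](C)C4)ccc3OC)cc2)c1` stands lowest: in a functional assay for agonist activity at growth hormone secretagogue receptor type 1 (Homo sapiens), read by FLIPR (a higher number here means that more compound is needed for the effect, a lower number that less compound is needed), compound 3 gives 0.398 nM, whereas compound 1 `CCOc1ccc(N2C[C@@H](C)N[C@@H](C)C2)cc1NS(=O)(=O)c1ccc(-c2ccccn2)s1` gives 39.8 nM and compound 2 `CC(=O)c1ccc(N2C[C@@H](C)N[C@@H](C)C2)cc1NS(=O)(=O)c1ccc(-c2ccccn2)s1` gives 39.8 nM, both far beyond the scatter from compound 3. Compound 4 `COc1ccc(N2C[C@@H](C)N[C@@H](C)C2)cc1NS(=O)(=O)c1ccc(N2CCCC2=O)cc1` differs from compound 3 in one place: 2-oxopyrrolidin-1-yl in place of 2-fluoro-5-methoxyphenyl on an aromatic carbon. Within the data shown here, the only recorded step, no change at the digits printed from compound 1 to compound 2 (within the scatter), alters a group elsewhere on the shared core and so does not speak to this position directly. Compound 1 and compound 2 carry a different group at this same place and sit well above compound 3, so a rise in this assay is expected, and the expected step is a 75-fold higher number from compound 3 to compound 4 (1.88 log units; beyond the scatter). Compound 4 is estimated at 30 nM, with a likely range from 5 nM to 200 nM.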

Compound 4, half-maximal effective concentration: 39.8 nM
For compound 4 the middle estimate is 1.3-fold (0.12 log units) below the measured one; the range from low to high includes it.
By their numbers in this assay, from the lowest: compound 3; then compounds 1, 2 and 4 (each within the scatter of the next).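

In this assay, putting 2-oxopyrrolidin-1-yl in place of 2-fluoro-5-methoxyphenyl gives a 100-fold higher number from compound 3 to compound 4 (2.00 log units; beyond the scatter). Among these compounds, this is the first direct one-place comparison at this aromatic carbon, and it shows that the number depends strongly on the group placed here. No measurement available here explains the size of this step.

As far as these compounds go, it remains open whether the low number of compound 3 needs only an aromatic ring of carbon at this place, or also its fluorine and methoxy groups. A plain phenyl group here would help separate these possibilities.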